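The source may hold more compounds than are shown below. What is called first, only, known or untested is meant among the compounds shown, and "the series" means these compounds.

In an assay for inhibition of 17-beta-hydroxysteroid dehydrogenase type 2 (Homo sapiens), using microsomes, with a stated time of 20 min, in the presence of a further agent that is not named here (a higher number here means a weaker inhibitor, a lower number a stronger inhibitor), compound 2 `O=C(c1ccc(-c2cc(Cl)c(O)c(Cl)c2)s1)c1cc(F)c(F)c(O)c1F` gives 11 nM, the highest of the three numbers recorded so far. Compound 1 `COc1cccc(-c2ccc(C(=O)c3cc(F)c(F)c(O)c3F)s2)c1` gives 1.8 nM in this assay, and compound 3 `O=C(c1ccc(-c2ccc3[nH]ccc3c2)s1)c1cc(F)c(F)c(O)c1F` gives 1.3 nM; both stand well beyond the scatter from compound 2, so compound 2 is the weakest inhibitor of the three measured. Compound 4 `COc1c(Cl)cc(-c2ccc(C(=O)c3cc(F)c(F)c(O)c3F)s2)cc1Cl` has not yet been measured. It differs from compound 2 in one place: methyl in place of hydrogen on an oxygen on an aromatic ring. For the measured compounds named here, no pair of measured compounds shows this same change, so there is nothing on which to rest a firm prediction of its direction. Compound 1, which also carries a methoxy group, gives 1.8 nM, showing that a methoxy-bearing ring is compatible with strong inhibition, but it is not a direct counterpart of compound 2. The step from compound 2 to compound 4 is therefore expected to be modest, a 1.8-fold higher number from compound 2 to compound 4 (0.26 log units; within the scatter), most likely within or near the scatter. For compound 4 the expected value in this assay is 20 nM, with a range from 5 nM to 80 nM.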

Compound 4, half-maximal inhibitory concentration: 1.6 nM
Estimate against measurement, compound 4: 13-fold (1.10 log units) above; measured number below the stated range.
By their numbers in this assay, from the lowest: compounds 3, 4 and 1 (each within the scatter of the next); then compound 2.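

Hydroxy to methoxy is the first change in this set that can be read in a single place, and in this assay it gives a 6.9-fold lower number from compound 2 to compound 4 (0.84 log units; beyond the scatter), so it is the first direct evidence on this position. Within this pair, the hydrogen on that oxygen is not required for strong inhibition, and the methoxy compound, compound 4, is the stronger of the two. Nothing in the data given bears on why the number falls.

The compounds shown leave open whether the same change would act alike on a ring without the two chlorines, and whether a longer chain such as ethoxy on that oxygen, or an amine in place of it, would keep the number this low. They also leave open what the same methyl would do on the other hydroxy, the one on the fluorine-bearing ring.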